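A Pyridylmethyl Group in Place of Methoxyphenyl on the Ring Nitrogen

This account rests on a few compounds, and the source may have more. Where it says the series, first, only, none or still open, it means among the compounds named here.

Three compounds have been measured in an assay on isolated protein for inhibition of methionine--tRNA ligase, cytoplasmic (Homo sapiens); a higher number here means a weaker inhibitor, a lower number a stronger inhibitor:

compound 1, `O=C(O)c1cc(-c2ccc(-c3ccc(Cl)cc3Cl)cc2)n(-c2ccc(Cl)cc2Cl)n1`: 11900 nM
compound 2, `O=C(O)c1cc(-c2ccc(-c3ccc(Cl)cc3Cl)cc2)n(-c2ccccn2)n1`: > 100000 nM
compound 3, `COc1ccc(-n2nc(C(=O)O)cc2-c2ccc(-c3ccc(Cl)cc3Cl)cc2)cc1`: > 100000 nM

Compound 1 is the only one of the three that gives a number. Compound 2 reaches only a limit of the assay. Compound 3 likewise reaches only a limit, and so compound 3 stands at the weak end of what is shown, where the limit of > 100000 nM in this assay, at which 2 of the 3 values shown sit, applies. The step of an at least 8.4-fold higher number from compound 1 to compound 2 (0.92 log units; beyond the scatter) and the step of an at least 8.4-fold higher number from compound 1 to compound 3 (0.92 log units; beyond the scatter) both run beyond the scatter, while the step that the two limits leave unreadable from compound 2 to compound 3 cannot be sized. Compound 4, `O=C(O)c1cc(-c2ccc(-c3ccc(Cl)cc3Cl)cc2)n(Cc2ccncc2)n1`, is not yet measured. The change is (pyridin-4-yl)methyl in place of 4-methoxyphenyl on an aromatic nitrogen. Both measured steps bear on it, since they show that replacing the 2,4-dichlorophenyl on that nitrogen with another aromatic group pushes the number past the limit. Compound 4 again carries no 2,4-dichlorophenyl there, so compound 4 is expected to stay near the limit, a step of a number no higher from compound 3 to compound 4 (the limit leaves the size open) being estimated. Compound 4 is therefore estimated at 100000 nM, between 30000 nM and 300000 nM.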

Compound 4, half-maximal inhibitory concentration: 26200 nM
The estimate for compound 4 lay 3.8-fold (0.58 log units) above the measured number, outside the stated range (below it).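

In this assay, (pyridin-4-yl)methyl on the aromatic nitrogen gives a readable number where 4-methoxyphenyl and pyridin-2-yl did not, with an at least 3.8-fold lower number from compound 3 to compound 4 (0.58 log units; beyond the scatter) and an at least 3.8-fold lower number from compound 2 to compound 4 (0.58 log units; beyond the scatter). Compound 2 and compound 3 each stand at a limit and not at a number, so these two steps give only a minimum size: the limit of > 100000 nM in this assay, at which 2 of the 4 values shown sit. This place therefore tolerates a group other than 2,4-dichlorophenyl without the number reaching the limit, though the swap still carries a cost, with a 2.2-fold higher number from compound 1 to compound 4 (0.34 log units; beyond the scatter).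

The compounds shown do not separate the contribution of the methyl link from that of the pyridine ring, which a benzyl group at this place would address. Going by these compounds, how (pyridin-2-yl)methyl, (pyridin-3-yl)methyl or a longer chain ending in pyridin-4-yl would compare also remains open.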